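A few compounds are considered here, and "the series" means these few. Any claim that something is new, unique, unknown or untested is made for them only; others in the source may bear on it.

Compound 1 `CCN(C(=O)OC)c1c(N)nc(-c2nn(Cc3ccccc3F)c3ncccc23)nc1N`: 11.7 mL/min/kg
Compound 2 `COC(=O)N(CCO)c1c(N)nc(-c2nn(Cc3ccccc3F)c3ncccc23)nc1N`: 61.7 mL/min/kg

Both values come from an ADME assay on cells (Hepatocyte, Rattus norvegicus) for pharmacokinetics, read by LC-MS, with a stated time of 90 min, tested at 1 uM; on this read-out higher numbers stand for fast clearance and lower numbers for slow clearance. Of the two compounds, compound 2 stands higher, at 61.7 mL/min/kg. Going by the values given here, the only measured step, a 5.3-fold higher number from compound 1 to compound 2 (0.72 log units; beyond the scatter), is modest but beyond the scatter. Compound 3 `COC(=O)N(Cc1ccccc1F)c1c(N)nc(-c2nn(Cc3ccccc3F)c3ncccc23)nc1N` has not yet been measured in this assay. It differs from compound 2 as follows: 2-fluorophenyl in place of hydroxymethyl on a saturated chain carbon bound to an amide-type nitrogen. This places 2-fluorophenyl in place of hydroxymethyl on a saturated chain carbon bound to an amide-type nitrogen, so that 2-hydroxyethyl gives way to 2-fluorobenzyl.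

Compound 3 thus has no hydroxy on this chain, and neither does compound 1, which gives 11.7 mL/min/kg. Among the compounds with values here, the single measured step therefore suggests a move back towards that lower number. Within the data shown here, no measured compound carries 2-fluorobenzyl at this place, however, so only a partial return is expected, and the uncertainty is wide. The expected change is a 2.5-fold lower number from compound 2 to compound 3 (0.39 log units; beyond the scatter). For compound 3 the estimated clearance is 25 mL/min/kg, with an expected range of 9 mL/min/kg to 65 mL/min/kg.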

Compound 3, clearance: 53.3 mL/min/kg
Compound 3: the middle estimate sits 2.1-fold (0.33 log units) below what was measured; the range from low to high includes it.
By their numbers in this assay, from the lowest: compound 1; then compounds 3 and 2 (each within the scatter of the next).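

In this assay the 2-hydroxyethyl chain of compound 2 and the 2-fluorobenzyl chain of compound 3 cannot be told apart, with a 1.2-fold lower number from compound 2 to compound 3 (0.06 log units; within the scatter) on exchanging one for the other. The earlier step had tied the high number to a hydroxy on this chain, but a chain without any hydroxy now gives a number within the scatter of the hydroxylated one, so the hydroxy is not needed for a high number at this place. Compared with the ethyl chain, the 2-fluorobenzyl chain shows a 4.6-fold higher number from compound 1 to compound 3 (0.66 log units; beyond the scatter) and so, among these three compounds, only the ethyl chain of compound 1 gives the low number. Nothing shown here bears on why these numbers fall as they do.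

The compounds shown leave open whether the low number belongs to ethyl alone or would carry over to a longer chain such as propyl. They also leave open whether plain benzyl would stand with 2-fluorobenzyl, and whether a 2-aminoethyl chain would stand with 2-hydroxyethyl.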